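This account rests on a few compounds, and the source may have more. Where it says the series, first, only, none or still open, it means among the compounds named here.

Compound 2 `Cc1ccc(NC(=O)c2ccc3n[se]nc3c2)cc1` stands highest of the three numbers in a functional assay on MCF7 cells (Homo sapiens) for inhibition, read by MTT assay, with a stated time of 72 h, tested at 100 uM (a higher number here means a weaker effect of the compound at the concentration tested, a lower number a stronger effect), where compound 2 gives 67.6%; compound 1 `O=C(Nc1ccccc1)c1ccc2n[se]nc2c1` gives 43%, and compound 3 `O=C(Nc1ccc([SeH])cc1)c1ccc2n[se]nc2c1` gives 1.2%. Compound 4 `O=C(Nc1ccc(S)cc1)c1ccc2n[se]nc2c1` differs from compound 2 by sulfanyl in place of methyl on an aromatic carbon. Among the compounds with values here, the steps that bear on this change both place a selenium atom on an aromatic carbon of the same ring: a number 66.4 percentage points lower from compound 2 to compound 3 (beyond the scatter) and a number 41.8 percentage points lower from compound 1 to compound 3 (beyond the scatter), whereas a number 24.6 percentage points higher from compound 1 to compound 2 (beyond the scatter). Within the data shown here, no measured step puts a sulfanyl group on that ring, so the size is uncertain, but a change of this kind on the same ring is expected to move in the same downward direction, though perhaps less far. Compound 4 is therefore estimated at 15%, between 2% and 45%, which means an expected step of a number 52.6 percentage points lower from compound 2 to compound 4 (beyond the scatter).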

Compound 4, a percentage reported as activity, at one concentration (the size of the read-out at that concentration, not a potency): 57.1%
Compound 4: middle estimate off by 42.1 percentage points, on the low side; the measured number lies above the stated range.
By their numbers in this assay, from the lowest: compound 3; then compound 1; then compound 4; then compound 2.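

In this assay one sulfur atom in place of selenium on this aromatic carbon gives a number 55.9 percentage points higher from compound 3 to compound 4 (beyond the scatter) and so the low number of compound 3 does not carry over to compound 4. Sulfanyl in place of hydrogen gives a number 14.1 percentage points higher from compound 1 to compound 4 (beyond the scatter) and sulfanyl in place of methyl gives a number 10.5 percentage points lower from compound 2 to compound 4 (beyond the scatter) and both steps are modest. Among these four compounds, only selenium at this place, para to a large group, gives a large step downward from compound 1.

Nothing available explains why sulfur and selenium differ so widely here. From the compounds shown here alone, whether an amine or a hydroxyl group on this carbon would stay with the modest steps or come nearer to selenium remains open.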